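This account rests on a few compounds, and the source may have more. Where it says the series, first, only, none or still open, it means among the compounds named here.

Of the compounds shown here, two have so far been read in a physicochemical assay for metabolic stability, read by LC-MS, in simulated gastric fluid, with a stated time of 15 min, tested at 50 uM; on this read-out higher numbers stand for a more stable compound and lower numbers for a less stable compound. Compound 1 (`COc1cccc(CNC(=O)c2c(C)nc3cc(C)ccn23)c1`) gives 100%, while compound 2 (`CCC(=O)c1ccccc1OC(=O)c1coc(-c2ccccc2)n1`) gives 1.8%. Compound 2 therefore holds the lower of the two numbers, and its gap to compound 1 lies well beyond the scatter. Among the compounds with values here, no two measured compounds differ in only one place, so the data give no direct measure of what a single change does in this assay.

The next compound to be tested is compound 3 (`Cc1ccccc1OC(=O)c1coc(-c2ccccc2)n1`), which departs from compound 2 at one place: methyl in place of propanoyl on an aromatic carbon. In short, it carries methyl in place of propanoyl on an aromatic carbon. A rise beyond the scatter is the expected direction in this assay, because compound 2 stands at 1.8% and has almost no room to fall. The size of that rise is poorly constrained, so a wide range is expected. The estimated change is a number 33.2 percentage points higher from compound 2 to compound 3 (beyond the scatter). For compound 3 the expected value is 35%, within an estimated range of 6% to 85%.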

Compound 3, percent of the compound remaining: 1.5%
Beside the measured number, compound 3's estimate is 33.5 percentage points above it; the whole stated range lies above it.
By their numbers in this assay, from the lowest: compounds 3 and 2 (each within the scatter of the next); then compound 1.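

Within the data shown here, the exchange of propanoyl for methyl on an aromatic carbon, ortho to a large group, is the first single change that can be read in this assay, and it gives a number 0.3 percentage points lower from compound 2 to compound 3 (within the scatter). At this position, then, a group of 4 heavy atoms with a double bond and a hydrogen-bond acceptor can give way to a single carbon without moving the reading beyond the scatter, and compound 2 at 1.8% and compound 3 at 1.5% both lie far down the scale. There is no evidence here that bears on why the reading holds across this change.

Going by these compounds, whether an amine, a carboxylic acid or a longer chain in this same place would give a reading beyond the scatter of these two values remains open. Also open, on these data alone, is whether any change elsewhere in the structure shared by compound 2 and compound 3 would move the number, since this one step tests only a single position with a single pair of groups.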